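Benzyl fluorination on the shared core: predicting compound 4

The compounds below may be only part of what the source reports. "The series", "measured", "known", "first", "only" and "open" are said of these compounds alone.

Compound 1 `Cc1cccc(CN2Cc3c(NC(=O)c4ccccc4)n[nH]c3C2(C)C)c1` is the reference point of this small set. In an assay on Sf21 cells for inhibition of high affinity nerve growth factor receptor (Homo sapiens), read by HTRF, with a stated time of 30 min, in the presence of a further agent that is not named here (on this read-out higher numbers stand for weaker inhibition and lower numbers for stronger inhibition), compound 1 gives 1100 nM, the highest of the three numbers measured. Its nearest neighbour is compound 2 `CC1(C)c2[nH]nc(NC(=O)c3ccccc3)c2CN1Cc1cccc(Cl)c1`, which in this assay gives 670 nM, so that a 1.6-fold lower number from compound 1 to compound 2 (0.22 log units; within the scatter). Compound 3 `CC1(C)c2[nH]nc(NC(=O)c3ccccc3)c2CN1Cc1cc(F)cc(F)c1` stands furthest away: in this assay compound 3 gives 190 nM, and a 5.8-fold lower number from compound 1 to compound 3 (0.76 log units; beyond the scatter), while a 3.5-fold lower number from compound 2 to compound 3 (0.55 log units; beyond the scatter).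

Compound 4 `CC1(C)c2[nH]nc(NC(=O)c3ccccc3)c2CN1Cc1ccc(F)cc1F` has not yet been measured. It differs from compound 1 in one place: 2,4-difluorophenyl in place of 3-methylphenyl on a saturated chain carbon bound to an amine nitrogen in a ring. Among the measured compounds shown here, the steps that bear on this change are those leading to compound 3, where two fluorines entered in place of a methyl or a chloro substituent and the number fell by a modest but real amount. For the measured compounds named here, compound 4 also carries two fluorines, though arranged as 2,4-difluorophenyl rather than 3,5-difluorophenyl, and no measured pair in this set shows what that arrangement does. The account therefore expects a step in the same direction as that from compound 1 to compound 3, but smaller, because only a 5.8-fold lower number from compound 1 to compound 3 (0.76 log units; beyond the scatter) and a 3.5-fold lower number from compound 2 to compound 3 (0.55 log units; beyond the scatter) are known and neither tests this exact pattern. For compound 4 the estimate in this assay is 450 nM, expected to lie between 150 nM and 1300 nM, which means an expected 2.4-fold lower number from compound 1 to compound 4 (0.39 log units; beyond the scatter).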

Compound 4, half-maximal inhibitory concentration: 2320 nM
Compound 4: the middle estimate sits 5.2-fold (0.71 log units) below what was measured; the whole stated range lies below it.
By their numbers in this assay, from the lowest: compound 3; then compounds 2 and 1 (each within the scatter of the next); then compound 4.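

With the same two fluorines present, the step from 3,5-difluorophenyl to 2,4-difluorophenyl in this assay gives a 12-fold higher number from compound 3 to compound 4 (1.09 log units; beyond the scatter) and is the largest step in the set, so at this place, on a saturated chain carbon bound to an amine nitrogen in a ring, the count of fluorines alone does not fix the number and their arrangement matters. The replacements of 3-methylphenyl and 3-chlorophenyl also come out differently for the two difluorophenyl groups: 2,4-difluorophenyl gives a 2.1-fold higher number from compound 1 to compound 4 (0.32 log units; beyond the scatter) and a 3.5-fold higher number from compound 2 to compound 4 (0.54 log units; beyond the scatter), so the lower number seen for compound 3 does not extend to difluorophenyl groups in general, and compound 4 goes against any such pattern. Nothing measured here explains why the two arrangements differ.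

The compounds shown leave open whether a phenyl group with a single fluorine would stand nearer to compound 3 or to compound 4. They also leave open how methoxy or nitrile substituents on this phenyl group, or a longer chain from the ring amine nitrogen to it, would compare.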